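Aryl Ether Exchange on the Macrolide Core

This account rests on a few compounds, and the source may have more. Where it says the series, first, only, none or still open, it means among the compounds named here.

Compound 1 `CC[C@@H]1/C=C(\C)C[C@H](C)C[C@H](OC)[C@H]2O[C@@](O)(C(=O)C(=O)N3CCCC[C@H]3C(=O)O[C@H](/C(C)=C/[C@@H]3CC[C@@H](Oc4cccc(C)c4)[C@H](OC)C3)[C@H](C)[C@@H](O)CC1=O)[C@H](C)C[C@@H]2OC` stands at the higher of the two numbers recorded: in a functional assay on cells for inhibition, with Murine T-cell line (Mus musculus) as the target (a lower number here means a stronger inhibitor, a higher number a weaker inhibitor), compound 1 gives 5.4 nM, whereas compound 2 `CC[C@@H]1/C=C(\C)C[C@H](C)C[C@H](OC)[C@H]2O[C@@](O)(C(=O)C(=O)N3CCCC[C@H]3C(=O)O[C@H](/C(C)=C/[C@@H]3CC[C@@H](O)[C@H](Oc4ccc(OC)cc4)C3)[C@H](C)[C@@H](O)CC1=O)[C@H](C)C[C@@H]2OC` gives 0.9 nM in this assay, a gap beyond the usual scatter. Compound 3 `CC[C@@H]1/C=C(\C)C[C@H](C)C[C@H](OC)[C@H]2O[C@@](O)(C(=O)C(=O)N3CCCC[C@H]3C(=O)O[C@H](/C(C)=C/[C@@H]3CC[C@@H](Oc4ccc(N(C)C)cc4)[C@H](OC)C3)[C@H](C)[C@@H](O)CC1=O)[C@H](C)C[C@@H]2OC` is compound 1 with 4-(dimethylamino)phenyl in place of 3-methylphenyl on an oxygen on a saturated carbon; it has not yet been measured. Among the measured compounds shown here, no step between measured compounds isolates this change, so he expects a step from compound 1 to compound 3 of a 1.4-fold lower number from compound 1 to compound 3 (0.13 log units; within the scatter) in this assay, not clearly beyond the scatter in either direction. Compound 3 is therefore estimated at 4 nM, with a range from 1.5 nM to 12 nM.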

Compound 3, half-maximal inhibitory concentration: 1.1 nM
Beside the measured number, compound 3's estimate is 3.6-fold (0.56 log units) above it; the measured number lies below the stated range.
By their numbers in this assay, from the lowest: compounds 2 and 3 (each within the scatter of the next); then compound 1.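

In this assay the exchange of 3-methylphenoxy for 4-(dimethylamino)phenoxy gives a 4.9-fold lower number from compound 1 to compound 3 (0.69 log units; beyond the scatter) with the rest of the molecule unchanged, so the aryl group on this oxygen alone can move the number beyond the scatter. Compound 1 and compound 2 differ in more than one place and could not show this. Nothing measured here accounts for the step.

As far as these compounds go, it remains open whether the step follows from the dimethylamino group itself or from its place on the ring. Neither 4-methylphenyl nor 3-(dimethylamino)phenyl stands among the compounds shown.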